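Sulfonyl aryl group swap in the benzylamide series

This account rests on a few compounds, and the source may have more. Where it says the series, first, only, none or still open, it means among the compounds named here.

Compound 3 `O=C(NCc1ccc(CNS(=O)(=O)c2ccc3c(c2)CCO3)cc1)c1ccc(F)cc1` carries the nine-atom bicyclic group on the sulfonyl sulfur; in an assay on MDA-MB-231 cells for binding affinity to C-X-C chemokine receptor type 4 (Homo sapiens), read by fluorescence and microscopy, with stated times of 10 min and 30 min (on this read-out lower numbers stand for an effect already at smaller amounts and higher numbers for an effect only at larger amounts of compound), compound 3 gives 10 nM. Compound 2 `O=C(NCc1ccc(CNS(=O)(=O)c2ccccc2F)cc1)c1ccc(F)cc1` gives 10 nM, and the two stand together at the lowest number of three, with no change at the digits printed from compound 2 to compound 3 (within the scatter). Compound 1 `Cc1ccccc1S(=O)(=O)NCc1ccc(CNC(=O)c2ccc(F)cc2)cc1` gives 100 nM, so compound 3 lies well off it: a 10-fold lower number from compound 1 to compound 3 (1.00 log units; beyond the scatter).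

Compound 4 `Cc1cccc(S(=O)(=O)NCc2ccc(CNC(=O)c3ccc(F)cc3)cc2)c1` differs from compound 3 by a group of 7 heavy atoms (7 carbon; one six-membered aromatic ring of carbon only) in place of a group of 9 heavy atoms (8 carbon, 1 oxygen; one five-membered non-aromatic ring with 1 hetero atom, one six-membered aromatic ring of carbon only), on a sulfonyl sulfur. The nearest measured steps are a 10-fold lower number from compound 1 to compound 3 (1.00 log units; beyond the scatter) and a 10-fold lower number from compound 1 to compound 2 (1.00 log units; beyond the scatter), both shown as modest and both involving a seven-heavy-atom all-carbon aromatic group on the same sulfur, as compound 4 now brings back. Among the measured compounds shown here, no step covers 3-methylphenyl itself. Compound 4 is therefore expected to move toward compound 1, a 4.0-fold higher number from compound 3 to compound 4 (0.60 log units; beyond the scatter), estimated at 40 nM with a range of 10 nM to 160 nM.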

Compound 4, effective concentration (reported as EC, without a stated level of effect): 1 nM
Beside the measured number, compound 4's estimate is 40-fold (1.60 log units) above it; the measured number lies below the stated range.
By their numbers in this assay, from the lowest: compound 4; then compounds 2 and 3 (each within the scatter of the next); then compound 1.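

In this assay, among the compounds shown here, moving the methyl group on the sulfonyl aryl ring, as 3-methylphenyl in place of 2-methylphenyl, gives a 100-fold lower number from compound 1 to compound 4 (2.00 log units; beyond the scatter) and is the only large step in the set. The same group also improves on the earlier aryl groups, with a 10-fold lower number from compound 2 to compound 4 (1.00 log units; beyond the scatter) and a 10-fold lower number from compound 3 to compound 4 (1.00 log units; beyond the scatter) as the steps. The level shared by compound 2 and compound 3 is therefore not the lowest reachable at this position.

From the compounds shown here alone, whether 3-chlorophenyl or 3-ethylphenyl on the sulfonyl sulfur would hold this level remains open. Nothing available explains why this change has so large an effect.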